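Adding a Methyl to a Compound That Showed No Inhibition

The source may report more compounds than this note shows. Statements on the series, on what has been measured and on what is new or still open speak of the compounds shown alone.

Compound 3 `CC(C)C(NC(=O)n1nnc2ccccc21)C(=O)NC1CCCCC1` and compound 2 `CCC(C)C(NC(=O)n1nnc2ccccc21)C(=O)NC1CCCCC1` share one core and differ by a single change, (methyl in place of hydrogen on a saturated chain carbon, three bonds along the chain from an amide-type nitrogen and a carbonyl carbon). In a functional assay on L1210 cells (Mus musculus) for inhibition (on this read-out lower numbers stand for stronger inhibition and higher numbers for weaker inhibition), compound 3 gives 108000 nM and compound 2 gives 109000 nM, so the step is a 1.0-fold higher number from compound 3 to compound 2 (0.00 log units; within the scatter). Compound 1 `CC(C)C(NC(=O)NO)C(=O)NC1CCCC1` has a different core, and how it differs from compound 3 is not broken down here. In this assay compound 1 reaches only a limit of the assay, > 200000 nM, which is the limit of > 200000 nM in this assay, at which 1 of the 3 values shown sits. Compound 4 `CCC(C)C(NC(=O)NO)C(=O)NC1CCCC1` arises from compound 1 by the same change, (methyl in place of hydrogen on a saturated chain carbon, three bonds along the chain from an amide-type nitrogen and a carbonyl carbon). Because a 1.0-fold higher number from compound 3 to compound 2 (0.00 log units; within the scatter) stayed within the scatter, the step expected is a step that the limit leaves unreadable from compound 1 to compound 4. Compound 4 is therefore estimated at 250000 nM, with a range from 100000 nM to 600000 nM, most likely again reported only as a limit.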

Compound 4, half-maximal inhibitory concentration: > 100000 nM
Compound 4: only a limit was reported (the forecaster's own chance of this, stated with the estimate: 80%); the middle value lies beyond the limit too.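

Compound 1 and compound 4 are both reported only as limits, and the step between them cannot be read. From the compounds shown here alone, whether the methyl alters inhibition on the core of compound 1 stays open.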